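The source may report more compounds than this note shows. Statements on the series, on what has been measured and on what is new or still open speak of the compounds shown alone.

Measured in a functional assay on MCF7 cells (Homo sapiens) for antiproliferative activity, read by MTT assay, with a stated time of 48 h; on this read-out lower numbers stand for stronger inhibition and higher numbers for weaker inhibition:
- compound 1 `COc1ccc(C(=O)c2ccc(OC)c3c2C=CC(C)(C)O3)c(NC(=O)CO)c1`: 940 nM
- compound 2 `CNCC(=O)Nc1cc(OC)ccc1C(=O)c1ccc(OC)c2c1OC(C)(C)C=C2`: 820 nM

Going by the values given here, the two values lie within the scatter of each other, so compound 1 stands level with the only other measured compound. Compound 3 `COc1ccc(C(=O)c2ccc(OC)c3c2C=CC(C)(C)O3)c(NC(=O)CN(C)C)c1` has not yet been measured. It departs from compound 1 by dimethylamino in place of hydroxy on a saturated chain carbon bound to a carbonyl carbon, with dimethylamino in place of hydroxy on a saturated chain carbon bound to a carbonyl carbon. Among the compounds with values here, no single-place step has been measured, so the guide is thin: compound 1 gives 940 nM and compound 2 gives 820 nM, despite their different side chains. In this assay no change beyond the scatter is expected, and the estimated 1.2-fold lower number from compound 1 to compound 3 (0.07 log units; within the scatter) is small. For compound 3 the expected value is 800 nM, with an estimated range of 300 nM to 2100 nM.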

Compound 3, half-maximal inhibitory concentration: 6530 nM
Compound 3: middle estimate off by 8.2-fold (0.91 log units), on the low side, and the stated range ends below it.
By their numbers in this assay, from the lowest: compounds 2 and 1 (each within the scatter of the next); then compound 3.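

In this assay, going by these compounds alone, dimethylamino in place of hydroxy on a saturated chain carbon bound to a carbonyl carbon gives a 6.9-fold higher number from compound 1 to compound 3 (0.84 log units; beyond the scatter), the only single-place step at hand. It shows that, on the core of compound 1, this position does not accept both groups alike: a change in this one group alone moves the number beyond the scatter. Nothing measured explains this step.

As far as these compounds go, whether methylamino, methoxy or a longer chain at this place would stay close to compound 1 remains open. So does whether the step comes from losing hydroxy or from adding dimethylamino.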